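The compounds below may be only part of what the source reports. "The series", "measured", "known", "first", "only" and "open" are said of these compounds alone.

Measured compounds:

Compound 1, `COc1nsnc1C(=O)Nc1cc(C(F)(F)F)cc(C(F)(F)F)c1`: in an assay on isolated protein for inhibition of mitogen-activated protein kinase kinase kinase 14 (Homo sapiens), read by ADP-Glo, with a stated time of 60 min, in the presence of a further agent that is not named here (on this read-out higher numbers stand for weaker inhibition and lower numbers for stronger inhibition), compound 1 gives > 100000 nM, which is a limit of the assay and not a number.
Compound 2, `O=C(Nc1cccc(C(F)(F)F)c1)c1nsnc1O`: in this assay compound 2 gives > 100000 nM, again a limit of the assay.
Compound 3, `O=C(Nc1cc(C(F)(F)F)cc(C(F)(F)F)c1)c1nonc1O`: in this assay compound 3 gives > 100000 nM, also a limit of the assay.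

Compound 3 therefore stands nowhere on a scale of numbers: all three measured values sit at the same limit, as the limit of > 100000 nM in this assay, at which 3 of the 3 values shown sit, shows, and no measured inhibition is known for any of them.

Compound 4 is `O=C(Nc1cccc(C(F)(F)F)c1)c1nonc1O`. The change from compound 3 to compound 4 is hydrogen in place of trifluoromethyl on an aromatic carbon. Within the data shown here, only one pair of measured compounds differs in a single place, and that step, a step that the two limits leave unreadable from compound 1 to compound 3, cannot be given a size. Compound 2 and compound 3 differ in more than one place, and their two values show only that both reach the limit. Among the measured compounds shown here, no measured step concerns a trifluoromethyl group being exchanged for hydrogen, so nothing in the data points to a change beyond the scatter.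

Compound 4 is expected to give 200000 nM, between 50000 nM and 1000000 nM, most likely reported again only as a limit. The expected step that the limit leaves unreadable from compound 3 to compound 4 is estimated to be none beyond the scatter.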

Compound 4, half-maximal inhibitory concentration: > 100000 nM
Compound 4: only a limit was reported (the forecaster's own chance of this, stated with the estimate: 90%); the middle value lies beyond the limit too.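

In this assay compound 4 gives > 100000 nM, which is a limit of the assay and not a number. The steps from compound 2 and from compound 3 to compound 4 cannot be read, because all the values share one limit: the limit of > 100000 nM in this assay, at which 4 of the 4 values shown sit.

The compounds shown leave open how strongly any of them inhibits this kinase, and which change would give a measurable value.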